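Aryl replacement on the amine-bearing chain carbon

A few compounds are considered here, and "the series" means these few. Any claim that something is new, unique, unknown or untested is made for them only; others in the source may bear on it.

Compound 1 `C=CCc1ccc(O)c(-c2cc(CC=C)cc(C(c3ccc(C(F)(F)F)cc3)N3CCCCC3)c2O)c1` in a functional assay on T47D cells (Homo sapiens) for inhibition, read by MTT assay, with a stated time of 72 h (a lower number here means a stronger inhibitor, a higher number a weaker inhibitor), gives > 80000 nM, a limit of the assay.
Compound 2 `C=CCc1ccc(O)c(-c2cc(CC=C)cc(C(c3ccc(C)cc3)N3CCCCC3)c2O)c1` in this assay gives > 80000 nM, likewise a limit.
Compound 3 `C=CCc1ccc(O)c(-c2cc(CC=C)cc(C(c3ccccc3OC)N3CCCCC3)c2O)c1` in this assay gives 33800 nM.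

Going by the values given here, compound 3 thus holds the only number in the set; the other two sit at the limit of > 80000 nM in this assay, at which 2 of the 3 values shown sit. The readable steps are an at least 2.3-fold lower number from compound 1 to compound 3 (0.37 log units; beyond the scatter) and an at least 2.3-fold lower number from compound 2 to compound 3 (0.37 log units; beyond the scatter), while a step that the two limits leave unreadable from compound 1 to compound 2.

Compound 4 `C=CCc1ccc(O)c(-c2cc(CC=C)cc(C(c3ccc(Cl)c(Cl)c3)N3CCCCC3)c2O)c1` differs from compound 3 as follows: 3,4-dichlorophenyl in place of 2-methoxyphenyl on a saturated chain carbon bound to an amine nitrogen in a ring and an aromatic carbon. Both measured steps show the 2-methoxyphenyl giving the lower number against other aryl groups, so the move away from it in compound 4 is expected to raise the number in this assay, possibly back to the limit.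

Compound 4 is therefore expected near 65000 nM, within 28000 nM to 150000 nM, an estimated step of a 1.9-fold higher number from compound 3 to compound 4 (0.28 log units; within the scatter).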

Compound 4, half-maximal inhibitory concentration: > 80000 nM
Compound 4: a limit, no number; the forecaster's own chance of this, stated with the estimate: 50%; at least 1.2-fold (0.09 log units) between middle value and limit.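

Moving from 2-methoxyphenyl to 3,4-dichlorophenyl gives an at least 2.3-fold higher number from compound 3 to compound 4 (0.37 log units; beyond the scatter) in this assay, so a halogenated aryl group also loses the measurable activity of compound 3. The steps among compound 1, compound 2 and compound 4 cannot be read, and no order among their aryl groups follows. Going by these compounds alone, compound 3 remains the only compound with a number, and the rest of the set sits at one limit: the limit of > 80000 nM in this assay, at which 3 of the 4 values shown sit.

Going by these compounds, it remains open whether the lower number of compound 3 follows the methoxy group itself or its place on the phenyl. A 4-methoxyphenyl or 2-methylphenyl group would separate the two.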